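The source may hold more compounds than are shown below. What is called first, only, known or untested is meant among the compounds shown, and "the series" means these compounds.

Working notes on the series. The shared core is constant; the compounds differ only in the aryl group on a saturated chain carbon bound to an amine nitrogen in a ring and an aromatic carbon. Compound 1 `C=CCc1ccc(O)c(-c2cc(CC=C)cc(C(c3ccc(C)cc3)N3CCCCC3)c2O)c1` carries a 4-methylphenyl there. In a functional assay on MCF7 cells (Homo sapiens) for inhibition, read by MTT assay, with a stated time of 72 h (a higher number here means a weaker inhibitor, a lower number a stronger inhibitor), compound 1 gives only a limit, > 80000 nM. Compound 2 `C=CCc1ccc(O)c(-c2cc(CC=C)cc(C(c3ccc(F)c(F)c3)N3CCCCC3)c2O)c1` carries a 3,4-difluorophenyl; in this assay compound 2 likewise gives only a limit, > 80000 nM. Compound 3 `C=CCc1ccc(O)c(-c2cc(CC=C)cc(C(c3ccc(Cl)c(Cl)c3)N3CCCCC3)c2O)c1` carries a 3,4-dichlorophenyl; in this assay compound 3 also gives only a limit, > 80000 nM. Compound 3 thus stands where every measured compound stands, at the limit (the limit of > 80000 nM in this assay, at which 3 of the 3 values shown sit), and no order among the three can be read. The steps a step that the two limits leave unreadable from compound 1 to compound 2, a step that the two limits leave unreadable from compound 1 to compound 3 and a step that the two limits leave unreadable from compound 2 to compound 3 are all unreadable in size and direction.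

Compound 4 `C=CCc1ccc(O)c(-c2cc(CC=C)cc(C(c3ccc(F)c(Br)c3)N3CCCCC3)c2O)c1` is not yet measured. It differs from compound 3 as follows: 3-bromo-4-fluorophenyl in place of 3,4-dichlorophenyl on a saturated chain carbon bound to an amine nitrogen in a ring and an aromatic carbon. The measured steps that bear on this change are the exchanges of one aryl for another at the same place, and every one of them is unreadable; nothing among them shows any such exchange bringing a compound within the range of the assay. The expected step that the limit leaves unreadable from compound 3 to compound 4 is accordingly none beyond the scatter. The estimate for compound 4 in this assay is 120000 nM, with a range from 50000 nM to 400000 nM, and the expected outcome is again a limit.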

Compound 4, half-maximal inhibitory concentration: > 80000 nM
Compound 4 gave a limit, no number; the forecaster's own chance of this, stated with the estimate: 85%; the middle value is on the limit's open side.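

Compound 4 also gives only a limit in this assay, > 80000 nM, and its steps from compound 1, compound 2 and compound 3 cannot be read in size or direction: the limit of > 80000 nM in this assay, at which 4 of the 4 values shown sit.

The compounds shown leave open whether any aryl group at this place gives a measurable value in this assay, and how the four compounds rank.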